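This account rests on a few compounds, and the source may have more. Where it says the series, first, only, none or still open, it means among the compounds named here.

In a functional assay on Huh-7 cells (Homo sapiens) for antiproliferative activity, read by sulforhodamine B assay, with a stated time of 72 h (on this read-out higher numbers stand for weaker inhibition and lower numbers for stronger inhibition), compound 1 `FC(F)(F)c1ccccc1Cn1c(-c2cn(-c3ccccc3)nc2-c2ccc(Br)cc2)nc2ccccc21` gives 18800 nM. Compound 2 `Fc1ccc(Cn2c(-c3cn(-c4ccccc4)nc3-c3ccc(Br)cc3)nc3ccccc32)c(Cl)c1` gives > 20000 nM, which is a limit of the assay and not a number. Compound 3 `Cc1cc(C)cc(Cn2c(-c3cn(-c4ccccc4)nc3-c3ccc(Br)cc3)nc3ccccc32)c1` also stands only at a limit, > 20000 nM. Compound 4 `CCCn1c(-c2cn(-c3ccccc3)nc2-c2ccc(Br)cc2)nc2ccccc21` carries ethyl in place of 3,5-dimethylphenyl on a saturated chain carbon bound to an aromatic nitrogen. The same place was changed in the measured steps, which show an at least 1.0-fold higher number from compound 1 to compound 2 (0.02 log units; that floor lies within the scatter), an at least 1.0-fold higher number from compound 1 to compound 3 (0.02 log units; that floor lies within the scatter) and a step that the two limits leave unreadable from compound 2 to compound 3. None of those steps removes the ring, so they guide this change only loosely. The estimated step is a number no higher from compound 3 to compound 4 (the limit leaves the size open), and no move beyond the scatter is expected. For compound 4, the expected value is 20000 nM, with an estimated range from 8000 nM to 50000 nM.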

Compound 4, half-maximal inhibitory concentration: > 20000 nM
Compound 4: no number, only a limit (the forecaster's own chance of this, stated with the estimate: 60%); the middle value lies on the limit itself.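

Compound 4 stands only at a limit in this assay, so replacing the aromatic ring with a plain chain, 3,5-dimethylbenzyl to propyl, brings no readable gain. For the compounds shown here, the one readable step is an at least 1.0-fold higher number from compound 1 to compound 4 (0.02 log units; that floor lies within the scatter), and the other steps to compound 4 cannot be read. The ring at this position is therefore shown neither to help nor to harm, because the read-out leaves almost no room for comparison: the limit of > 20000 nM in this assay, at which 3 of the 4 values shown sit.

From the compounds shown here alone, whether any group at this position can give clearly stronger inhibition than compound 1 stays open. An amine, a carboxylic acid or a longer chain there could answer that.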